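Carbamoyl for isopropyl on the piperazine of compound 2

This account rests on a few compounds, and the source may have more. Where it says the series, first, only, none or still open, it means among the compounds named here.

Of the compounds shown here, three sharing the same core have been measured in an ADME assay on microsomes from liver (Mus musculus) for metabolic stability, read by LC-MS, with a stated time of 10 min, tested at 0.5 uM; on this read-out higher numbers stand for a more stable compound and lower numbers for a less stable compound. Compound 1 `c1cnc(CN(CCCN2CCNCC2)[C@H]2CCCc3cccnc32)nc1` gives 78%, compound 3 `c1cnc2c(c1)CCC[C@@H]2N(CCCN1CCNCC1)Cc1cc2ccccc2cn1` gives 74%, and compound 2 `CC(C)N1CCN(CCCN(C[C@H]2Cc3ccccc3CN2)[C@H]2CCCc3cccnc32)CC1` gives 58%. Compound 2 stands lowest of the three: its gap to compound 3 and its gap to compound 1 both lie beyond the scatter. Among the compounds with values here, the one step between neighbours that differ in a single place, a number 4 percentage points lower from compound 1 to compound 3 (within the scatter), concerns a swap of isoquinolin-3-yl for pyrimidin-2-yl and lies within the scatter.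

Compound 4 `NC(=O)N1CCN(CCCN(C[C@H]2Cc3ccccc3CN2)[C@H]2CCCc3cccnc32)CC1` differs from compound 2 in one place: carbamoyl in place of isopropyl on an amine nitrogen in a ring. The change sits on an amine nitrogen in a ring of a six-membered non-aromatic ring with 2 nitrogen. Within the data shown here, no measured step touches that ring; the only step recorded, from compound 1 to compound 3, is at a different place and says nothing about this exchange. Compound 4 is therefore estimated, with wide uncertainty, at 65% (range 45% to 85%), which means an expected step of a number 7 percentage points higher from compound 2 to compound 4 (within the scatter) in this assay.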

Compound 4, percent of the compound remaining: 42%
For compound 4 the middle estimate is 23 percentage points above the measured one; measured number outside the range, below it.
By their numbers in this assay, from the lowest: compound 4; then compound 2; then compounds 3 and 1 (each within the scatter of the next).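

In this assay, within the data shown here, carbamoyl in place of isopropyl on an amine nitrogen in a ring gives a number 16 percentage points lower from compound 2 to compound 4 (beyond the scatter), so this position, which no earlier step touched, does respond to a change of group on this read-out. The two groups have the same count of heavy atoms, so the step comes with an exchange of atoms rather than a change in that count: carbamoyl carries a hydrogen-bond donor and a hydrogen-bond acceptor, and isopropyl carries neither. Nothing at hand bears on what lies behind this step.

As far as these compounds go, whether an acetyl or a methyl group on the same nitrogen would give a similar number remains open, as does the effect of a bare ring amine with the rest of compound 2 unchanged. Compound 1 and compound 3 differ from compound 2 in more than one place, so they cannot settle either question.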